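Fluoro to Trifluoromethyl: What to Expect of Compound 4

The compounds below may be only part of what the source reports. "The series", "measured", "known", "first", "only" and "open" are said of these compounds alone.

Compound 1 `COc1ccc(F)cc1Nc1cc(NC(=O)Nc2c(Cl)cccc2Cl)ncn1`: 85.5%
Compound 2 `COc1cc(NC(=O)Nc2cc(Nc3ccc(F)c(Cl)c3)ncn2)cc(OC)c1`: 77.5%
Compound 3 `COc1cc(NC(=O)Nc2cc(Nc3cc(F)ccc3OC)ncn2)cc(OC)c1`: 59.5%

In a functional assay on PC-9 cells (Homo sapiens) for inhibition, read by MTT assay, with a stated time of 48 h, tested at 10 uM (a lower number here means less inhibition, a higher number more inhibition at the concentration tested (going by the name of the read-out)), compound 3 stands lowest of the three numbers. The step of a number 26 percentage points lower from compound 1 to compound 3 (beyond the scatter) went with 3,5-dimethoxyphenyl in place of 2,6-dichlorophenyl on an amide-type nitrogen, and the step of a number 18 percentage points lower from compound 2 to compound 3 (beyond the scatter) with 5-fluoro-2-methoxyphenyl in place of 3-chloro-4-fluorophenyl on a nitrogen on an aromatic ring. Compound 4 `COc1cc(NC(=O)Nc2cc(Nc3cc(C(F)(F)F)ccc3OC)ncn2)cc(OC)c1` differs from compound 3 by trifluoromethyl in place of fluoro on an aromatic carbon, a trifluoromethyl in place of fluoro on an aromatic carbon, para to a methoxy group. Going by the values given here, neither measured step touches that group, so no measured step bears on this change, and no step beyond the scatter is expected. Compound 4 is therefore estimated at 60%, within 42% to 78%. The expected step of a number 0.5 percentage points higher from compound 3 to compound 4 (within the scatter) is small.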

Compound 4, a percentage reported as inhibition, at one concentration (the size of the read-out at that concentration, not a potency): 81.1%
Compound 4: middle estimate off by 21.1 percentage points, on the low side; measured number above the stated range.
By their numbers in this assay, from the lowest: compound 3; then compounds 2, 4 and 1 (each within the scatter of the next).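

The carbon para to a methoxy group is sensitive to what it carries: in this assay trifluoromethyl in place of fluoro gives a number 21.6 percentage points higher from compound 3 to compound 4 (beyond the scatter) at that spot. Going by these compounds alone, none of the earlier steps changed this group, so this is the first sign that it matters here. Nothing at hand says why the number rises.

Going by these compounds, whether a nitrile or a methyl on this carbon would match trifluoromethyl stays open. So does whether the same change would hold with the 2,6-dichlorophenyl of compound 1 on the amide-type nitrogen.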